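A hydroxypyrrolidine in place of a benzylic hydroxy

This account rests on a few compounds, and the source may have more. Where it says the series, first, only, none or still open, it means among the compounds named here.

Measured in a functional assay on HeLa cells (Homo sapiens) for antiproliferative activity, read by CCK-8 assay, with a stated time of 48 h; on this read-out lower numbers stand for stronger inhibition and higher numbers for weaker inhibition:
- Compound 1 `COc1ccc(/C=C\c2cc(OC)c(OC)c(OC)c2)cc1OCc1ccc(CN2C[C@H](O)C[C@@H]2C(=O)O)cc1`: > 10000 nM, a limit of the assay
- Compound 2 `COc1ccc(/C=C\c2cc(OC)c(OC)c(OC)c2)cc1OCc1ccc(CO)cc1`: 7600 nM

Among these measurements, compound 2 stands alone with an actual number, 7600 nM in this assay. For compound 1 the reading is only a limit: the limit of > 10000 nM in this assay, at which 1 of the 2 values shown sits.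

The next compound is compound 3 `COc1ccc(/C=C\c2cc(OC)c(OC)c(OC)c2)cc1OCc1ccc(CN2CC[C@H](O)C2)cc1`, which differs from compound 2 as follows: 3-hydroxypyrrolidin-1-yl in place of hydroxy on a saturated chain carbon bound to an aromatic carbon. In words, 3-hydroxypyrrolidin-1-yl stands in place of hydroxy on a saturated chain carbon bound to an aromatic carbon.

Among the measured compounds shown here, one measured step bears on this change, since compound 1 carries 2-carboxy-4-hydroxypyrrolidin-1-yl at that same place: an at least 1.3-fold lower number from compound 1 to compound 2 (0.11 log units; that floor lies within the scatter). That step rests on a limit and its floor lies within the scatter, so it gives no firm size and no firm direction for the new change. A small move toward a lower number is the best guess, but no step beyond the scatter is expected. The estimated step is a 1.7-fold lower number from compound 2 to compound 3 (0.23 log units; within the scatter). A report as a limit also remains possible. In this assay the estimate for compound 3 is 4500 nM, with an expected range from 700 nM to 15000 nM.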

Compound 3, half-maximal inhibitory concentration: 10500 nM
Estimate against measurement, compound 3: 2.3-fold (0.37 log units) below; low and high end bracket the measured number.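

Exchanging hydroxy for 3-hydroxypyrrolidin-1-yl on a saturated chain carbon bound to an aromatic carbon gives, in this assay, a 1.4-fold higher number from compound 2 to compound 3 (0.14 log units; within the scatter). Among the compounds shown here, this is the first actual number for a pyrrolidine at this place, and it shows that a five-membered non-aromatic ring with a nitrogen can replace the hydroxy without a change that stands clear of the scatter. Compound 1 is reported only as a limit, so its step to compound 3 cannot be read, and the part played by the carboxy group on its ring stays unresolved because of that limit: the limit of > 10000 nM in this assay, at which 1 of the 3 values shown sits.

Since neither group shown with an actual number separates from the other at this place, it remains open whether any group there can move the read-out beyond the scatter. An unsubstituted pyrrolidine would speak to whether the ring hydroxy matters, and a morpholine or a simple primary amine would show whether the read-out depends on the ring itself or on the nitrogen alone.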